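Ring Amide Swap Tested on Pancreatic Cancer Cells

This account rests on a few compounds, and the source may have more. Where it says the series, first, only, none or still open, it means among the compounds named here.

Compound 3 `CCN(CC)S(=O)(=O)c1ccc(S(=O)(=O)N2CCC[C@@H](C(=O)N[C@@H]3CCOC3)C2)cc1` gives 2270 nM in a functional assay on BXPC-3 cells (Homo sapiens) for inhibition, read by MTT assay, with a stated time of 7 days; a higher number here means a weaker inhibitor, a lower number a stronger inhibitor. Among the three measured compounds, compound 3 holds the second-highest number: compound 2 `CCN(CC)S(=O)(=O)c1ccc(S(=O)(=O)N2CCC[C@@H](C(=O)N3CCC(COC)CC3)C2)cc1` gives 1360 nM, a gap within the scatter, while compound 1 `CCN(CC)S(=O)(=O)c1ccc(S(=O)(=O)N2CCC[C@@H](C(=O)NC3CCOCC3)C2)cc1` gives 8570 nM, a difference described by a 3.8-fold lower number from compound 1 to compound 3 (0.58 log units; beyond the scatter). Compound 4 `CCN(CC)S(=O)(=O)c1ccc(S(=O)(=O)N2CCC[C@@H](C(=O)N3CC[C@H](OC)C3)C2)cc1` differs from compound 3 by 3-methoxypyrrolidin-1-yl in place of (oxolan-3-yl)amino on a carbonyl carbon. The closest measured precedent is the exchange of (oxan-4-yl)amino for 4-(methoxymethyl)piperidin-1-yl, which likewise removes the amide hydrogen: a 6.3-fold lower number from compound 1 to compound 2 (0.80 log units; beyond the scatter). The comparison a 1.7-fold higher number from compound 2 to compound 3 (0.22 log units; within the scatter) shows the two ring amides sitting close together. Compound 4 is therefore expected to move by a 1.9-fold lower number from compound 3 to compound 4 (0.28 log units; within the scatter), an estimated 1200 nM in this assay, with a range from 400 nM to 4000 nM.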

Compound 4, half-maximal inhibitory concentration: 6750 nM
For compound 4 the middle estimate is 5.6-fold (0.75 log units) below the measured one; the measured number lies above the stated range.
By their numbers in this assay, from the lowest: compounds 2 and 3 (each within the scatter of the next); then compounds 4 and 1 (each within the scatter of the next).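

In this assay, removing the amide hydrogen does not bring a gain on its own: there is a 3.0-fold higher number from compound 3 to compound 4 (0.47 log units; beyond the scatter), and the other ring amide stays ahead, with a 5.0-fold higher number from compound 2 to compound 4 (0.70 log units; beyond the scatter). Compound 4 lacks that hydrogen and compound 1 keeps it, yet they do not separate, with a 1.3-fold lower number from compound 1 to compound 4 (0.10 log units; within the scatter), so the amide hydrogen alone does not track the numbers across these compounds. Nothing shown explains these shifts. Still open, from the compounds shown here alone, is how a piperidin-1-yl with no methoxymethyl chain, or a pyrrolidin-1-yl carrying an amine in place of methoxy, would read in this assay.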